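Cyclohexyloxy for propoxy on two cores in this assay

This account rests on a few compounds, and the source may have more. Where it says the series, first, only, none or still open, it means among the compounds named here.

Measured so far:
compound 1, `CCCOc1nc(CC2(c3ccccc3)CO2)cc(=O)n1C` — > 330000 nM (a limit of the assay)
compound 2, `Cn1c(OC2CCCCC2)nc(CC2(c3ccccc3)CO2)cc1=O` — > 294000 nM (a limit of the assay)
compound 3, `CCCOc1nc(CC2(C)CCCO2)cc(=O)n1C` — 860000 nM

In a functional assay on MDCK cells (Canis lupus familiaris) for inhibition (on this read-out lower numbers stand for higher toxicity in this test and higher numbers for lower toxicity in this test), compound 1 gives only a limit, > 330000 nM. Compound 2 likewise gives only a limit in this assay, > 294000 nM. Among the measured compounds shown here, compound 3 is the one compound with a number in this assay, 860000 nM. The change from compound 1 to compound 2 is cyclohexyl in place of propyl on an oxygen on an aromatic ring; the step it made, a step that the two limits leave unreadable from compound 1 to compound 2, cannot be read, since both ends are limits (the limit of > 294000 nM in this assay, at which 1 of the 3 values shown sits; (the limit of > 330000 nM in this assay, at which 1 of the 3 values shown sits)). The difference between the core of compound 1 and the core of compound 3 is not broken down here.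

Compound 4, `Cn1c(OC2CCCCC2)nc(CC2(C)CCCO2)cc1=O`, is not yet measured. It stands to compound 3 as compound 2 stands to compound 1: cyclohexyl in place of propyl on an oxygen on an aromatic ring, the same change at the same place. The earlier pair leaves the size of this step unknown, so for compound 4 the expectation rests on compound 3 alone, at 860000 nM, with a step expected to stay within the usual scatter, a 1.4-fold lower number from compound 3 to compound 4 (0.16 log units; within the scatter). Compound 4 is therefore estimated at 600000 nM in this assay, between 150000 nM and 1500000 nM.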

Compound 4, half-maximal cytotoxic concentration: 816000 nM
Beside the measured number, compound 4's estimate is 1.4-fold (0.13 log units) below it; measured number inside the range.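

In this assay, cyclohexyl in place of propyl on the core of compound 3 gives a 1.1-fold lower number from compound 3 to compound 4 (0.02 log units; within the scatter), so on this core the propoxy and cyclohexyloxy compounds cannot be told apart. The same change on the core of compound 1 cannot be read, since both ends of that pair are limits of the assay: the limit of > 330000 nM in this assay, at which 1 of the 4 values shown sits, and (the limit of > 294000 nM in this assay, at which 1 of the 4 values shown sits). The change therefore has one readable step, on one core, which shows that it can be made there without a step beyond the scatter, but does not show that the result carries over to the core of compound 1 or to any other core.

Going by these compounds, it remains open whether a chain ending in an amine or a carboxylic acid on the same oxygen would also stay within the scatter of compound 3 in this assay. Also open, on these data alone, is how large the step is on the core of compound 1, where neither end has a number.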